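This account rests on a few compounds, and the source may have more. Where it says the series, first, only, none or still open, it means among the compounds named here.

Measured compounds:

compound 1 `Cc1cc(/C=C2\SC(=O)NC2=O)c(C)n1-c1ccc(Br)cc1` gives 5370 nM in an assay for inhibition of glutaminase kidney isoform, mitochondrial (Homo sapiens), read by coupled enzyme assay, with stated times of 10 min and 60 min; a higher number here means a weaker inhibitor, a lower number a stronger inhibitor
compound 2 `Cc1cc(/C=C2\SC(=O)NC2=O)c(C)n1-c1ccc(-c2ccc(/C=C3\SC(=O)NC3=O)cc2)cc1` gives 381 nM in this assay
compound 3 `CCc1cc(-c2ccc(-n3c(C)cc(/C=C4\SC(=O)NC4=O)c3C)cc2C#N)ccc1/C=C1\SC(=O)NC1=O` gives 92 nM in this assay

Compound 2 holds the middle of the three numbers in this assay. Compound 1, carrying a single bromophenyl arm on the shared core, sits a long way above it, while compound 3, which carries the second benzylidene-thiazolidinedione arm together with ethyl and nitrile substituents on the linking ring, sits below it; both gaps lie beyond the usual scatter.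

Compound 4 `Cc1cc(/C=C2\SC(=O)NC2=O)c(C)n1-c1ccc(-c2ccc(/C=C3\SC(=O)NC3=O)cc2)c(O)c1` is not yet measured. It keeps the whole skeleton of compound 2 and differs by one change: hydroxy in place of hydrogen on an aromatic carbon

Going by the values given here, no measured pair isolates this kind of change, so the expected size of the step rests only on the spread seen between compound 2 and compound 3 in this assay. A small substituent added to the linking ring of compound 2 is expected to move the number by a modest amount, more likely downward than upward, but a result within the scatter is also plausible.

For compound 4 the estimate in this assay is 250 nM, with a range from 80 nM to 800 nM. This estimate corresponds to an expected step of a 1.5-fold lower number from compound 2 to compound 4 (0.18 log units; within the scatter).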

Compound 4, half-maximal inhibitory concentration: 760 nM
Beside the measured number, compound 4's estimate is 3.0-fold (0.48 log units) below it; the measured number falls inside the stated range.
By their numbers in this assay, from the lowest: compound 3; then compounds 2 and 4 (each within the scatter of the next); then compound 1.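

In this assay, going by these compounds alone, placing hydroxy in place of hydrogen on an aromatic carbon of the linking ring, ortho to a large group and meta to a large group, gives a 2.0-fold higher number from compound 2 to compound 4 (0.30 log units; within the scatter), the first step that isolates a change in one place. This ring position therefore accepts a hydroxy group, with its hydrogen-bond donor and acceptor, without a change in this assay that can be told apart from the scatter, so neither a gain nor a loss can be assigned to this substitution. No measurement shown gives a reason for this result or bears on how the hydroxy group acts at this position.

Still open, on these data alone, is whether a methoxy group, a fluorine atom, an amine or a carboxylic acid on this carbon would also stay within the scatter of compound 2, or whether hydroxy on another carbon of the ring would do the same. The separate contributions of the ethyl and nitrile groups in compound 3 also remain unresolved, as that compound differs from compound 2 in more than one place.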